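Anilino methylation on a pyrimidine series, cell growth

The source may hold more compounds than are shown below. What is called first, only, known or untested is meant among the compounds shown, and "the series" means these compounds.

Measured compounds:
compound 1 `C=CC(=O)Nc1cc(Nc2ncc(Cl)c(Nc3ccccc3S(=O)(=O)C(C)C)n2)c(OC)cc1N1CCN(C2CCCCC2)CC1` — < 0.3 nM
compound 2 `C=CC(=O)Nc1cc(Nc2ncc(Cl)c(Nc3cccc(C(F)(F)F)c3)n2)c(OC)cc1N1CCN(C)CC1` — 770 nM

In a functional assay on NCI-H3122 cells (Homo sapiens) for inhibition, read by CellTiter-Glo, with a stated time of 72 h (on this read-out lower numbers stand for stronger inhibition of growth and higher numbers for weaker inhibition of growth), compound 1 gives < 0.3 nM, which is a limit of the assay and not a number (the limit of < 0.3 nM in this assay, at which 1 of the 2 values shown sits). For the measured compounds named here, compound 2 gives 770 nM in this assay, the only numerical value in the set. Compound 3 `C=CC(=O)Nc1cc(Nc2ncc(Cl)c(N(C)c3cccc(C(F)(F)F)c3)n2)c(OC)cc1N1CCN(C)CC1` is not yet measured; it differs from compound 2 by methyl in place of hydrogen on a nitrogen on an aromatic ring. Going by the values given here, no measured pair isolates this change. The expected step from compound 2 to compound 3 is a loss beyond the scatter, a 3.2-fold higher number from compound 2 to compound 3 (0.51 log units; beyond the scatter). Compound 3 is estimated at 2500 nM, within 600 nM to 10000 nM.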

Compound 3, concentration for 50% growth inhibition: 3600 nM
The estimate for compound 3 lay 1.4-fold (0.16 log units) below the measured number; the measured number falls inside the stated range.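

In this assay, the nitrogen on an aromatic ring now has a single-change step, with methyl in place of hydrogen giving a 4.7-fold higher number from compound 2 to compound 3 (0.67 log units; beyond the scatter). This position therefore accepts methyl only with a loss of growth inhibition beyond the scatter, shown here only for the (3-(trifluoromethyl)phenyl)amino series member. Nothing measured here bears on the cause of this loss.

From the compounds shown here alone, whether an ethyl group or a longer chain on this nitrogen costs more than methyl remains open. Also open, going by these compounds, is whether methylation costs as much with the isopropylsulfonyl-bearing aniline and cyclohexylpiperazine of compound 1.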